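The source may report more compounds than this note shows. Statements on the series, on what has been measured and on what is new or still open speak of the compounds shown alone.

Measured compounds:
compound 1, `CCCC(=O)c1ccc(OCCCCOc2ccc(F)c(C(=O)O)c2)c(C)c1O`: 74 nM
compound 2, `Cc1cc(OCCCCOc2ccc(C(=O)CC3CCCC3)c(O)c2C)ccc1C(=O)O`: 564 nM

Both numbers come from an assay on HEK293 cells for positive allosteric modulation of metabotropic glutamate receptor 2 (Rattus norvegicus), read by thallium flux, with a stated time of 2.5 min; on this read-out lower numbers stand for an effect already at smaller amounts and higher numbers for an effect only at larger amounts of compound. Among the two measured compounds, compound 2 has the higher number; the nearest and only comparison is compound 1, whose value is lower by an amount well beyond the usual scatter. The two structures differ in more than one place, so the comparison does not isolate any single change.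

Compound 3, `Cc1c(OCCCCOc2ccc(F)c(C(=O)O)c2)ccc(C(=O)CC2CCCC2)c1O`, has not yet been measured in this assay. It differs from compound 2 in one place: 3-carboxy-4-fluorophenyl in place of 4-carboxy-3-methylphenyl on an oxygen on a saturated carbon. The rest of compound 2 is kept, including the ketone bearing the cyclopentyl group on the shared core. Compound 3 thereby carries the same 3-carboxy-4-fluorophenyl group that is found in compound 1.

Going by the values given here, no measured pair separates this change on its own. Still, a move toward a lower number seems the more likely direction, because compound 1 gives 74 nM with that same group. The step from compound 2 to compound 3 is expected to be a 4.3-fold lower number from compound 2 to compound 3 (0.64 log units; beyond the scatter) in this assay. For compound 3 the estimate is 130 nM, with a plausible range from 40 nM to 450 nM.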

Compound 3, half-maximal effective concentration: 699 nM
The estimate for compound 3 lay 5.4-fold (0.73 log units) below the measured number; the measured number lies above the stated range.
By their numbers in this assay, from the lowest: compound 1; then compounds 2 and 3 (each within the scatter of the next).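

In this assay, putting 3-carboxy-4-fluorophenyl in place of 4-carboxy-3-methylphenyl on an oxygen on a saturated carbon gives a 1.2-fold higher number from compound 2 to compound 3 (0.09 log units; within the scatter), so with the cyclopentyl ketone kept, this swap does not separate the two groups. The new compound also allows a second clean comparison with the 3-carboxy-4-fluorophenyl group held constant: cyclopentyl in place of ethyl on a saturated chain carbon bound to a carbonyl carbon gives a 9.4-fold higher number from compound 1 to compound 3 (0.98 log units; beyond the scatter), so among these three compounds, the change at the ketone end is the only single change that comes with a step beyond the scatter. Nothing shown here offers a measured explanation for either step.

Going by these compounds, it remains open whether the two carboxyphenyl groups would also match when ethyl rather than cyclopentyl sits on that chain carbon, since a single pair tests the swap in only one setting. On these data alone, how a cyclopropyl or a phenyl group would fare on the same chain carbon, and whether a tetrazole could stand in for the carboxylic acid, also remains open.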